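This account rests on a few compounds, and the source may have more. Where it says the series, first, only, none or still open, it means among the compounds named here.

Measured so far in a functional assay on the whole organism for positive allosteric modulation, with Mus musculus as the target; a higher number here means that more compound is needed for the effect, a lower number that less compound is needed:
- compound 1 `CCC(=O)N(c1ccc(Cl)c(Cl)c1)C1CCCC1O`: 0.4 mg/kg
- compound 2 `CCC(=O)N(c1ccc(OC)c(OC)c1)C1CCCC1N(C)C`: 9 mg/kg
- compound 3 `CCC(=O)N(c1ccc(C)c(Cl)c1)C1CCCC1N(C)C`: 1 mg/kg

Compound 1 has the lowest number of the three, so it needs the least compound for the effect. The gaps up to compound 3 and compound 2 both lie beyond the scatter.

The next compound is compound 4 `CCC(=O)N(c1ccc(Cl)c(Cl)c1)C1CCCC1N(C)Cc1ccccc1`. It keeps the core of compound 1 but carries benzyl(methyl)amino in place of hydroxy on a saturated ring carbon.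

For the measured compounds named here, no pair of measured compounds isolates this kind of change, and none carries a benzyl group, so the expectation is loose. An amino group in that place is not ruled out: compound 3, with a dimethylamino group there, gives 1 mg/kg, though it also differs from compound 1 elsewhere.

A rise beyond the scatter is expected, with more compound needed in this assay. The estimated change is a 7.5-fold higher number from compound 1 to compound 4 (0.88 log units; beyond the scatter). For compound 4 the expected value is 3 mg/kg, within an estimated range of 0.6 mg/kg to 15 mg/kg.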

Compound 4, dose for half-maximal effect: 0.2 mg/kg
For compound 4 the middle estimate is 15-fold (1.18 log units) above the measured one; the whole stated range lies above it.
By their numbers in this assay, from the lowest: compounds 4 and 1 (each within the scatter of the next); then compound 3; then compound 2.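

In this assay the swap of hydroxy for benzyl(methyl)amino gives a 2.0-fold lower number from compound 1 to compound 4 (0.30 log units; within the scatter) and so shows that this saturated ring carbon on the core of compound 1 can carry a much larger group, with 9 heavy atoms and a six-membered aromatic ring in place of 1 heavy atom, while the number stays within the scatter. The swap also removes the hydrogen-bond donor of hydroxy, so compound 4 shows that a donor in this place is not needed for a low number in this assay. Nothing at hand explains why two such different groups give numbers this close.

On these data alone, it remains open whether the benzyl part or the amine nitrogen matters more for this result. A primary amine, a carboxylic acid or a longer chain in this place could give quite different numbers.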